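Aryl ether to pyridyl swap on the acylurea series

The source may hold more compounds than are shown below. What is called first, only, known or untested is meant among the compounds shown, and "the series" means these compounds.

Compound 2 `COc1ccccc1C(=O)NC(=O)Nc1ccc(OCC(F)(F)F)c(C(F)(F)F)c1` holds the lowest of the two numbers in a physicochemical assay for solubility, in simulated intestinal fluid; on this read-out lower numbers stand for lower solubility and higher numbers for higher solubility: compound 2 gives 2.2 ug/mL. Among the measured compounds shown here, its nearest neighbour is compound 1 `COc1ccccc1C(=O)NC(=O)Nc1ccc(-c2ccccc2)c(C(C)C)c1`, which in this assay gives 24 ug/mL, a gap beyond the scatter; no single-change step between these two compounds is worked out, so only their two values are stated here. Compound 3 `COc1ccccc1C(=O)NC(=O)Nc1ccc(-c2ccccn2)c(C(F)(F)F)c1` has not yet been measured in this assay. The change from compound 2 is pyridin-2-yl in place of 2,2,2-trifluoroethoxy on an aromatic carbon. For the measured compounds named here, no measured step of this kind exists in the set, so the expectation rests on the two values alone. A small rise in this assay is expected, of a size that may not clear the scatter, giving the expected step of a 1.8-fold higher number from compound 2 to compound 3 (0.26 log units; within the scatter). Compound 3 is estimated at 4 ug/mL, with a range from 1 ug/mL to 15 ug/mL.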

Compound 3, solubility: 8.5 ug/mL
Compound 3: the middle estimate sits 2.1-fold (0.33 log units) below what was measured, and the stated range covers the measured number.
By their numbers in this assay, from the lowest: compound 2; then compound 3; then compound 1.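

Among the compounds shown here, replacing 2,2,2-trifluoroethoxy with pyridin-2-yl, on the aromatic carbon ortho to a trifluoromethyl group, gives a 3.9-fold higher number from compound 2 to compound 3 (0.59 log units; beyond the scatter) in this assay and provides the first single-change reading. This position therefore responds to the choice of group while the trifluoromethyl group stays fixed. The two groups match in heavy-atom and hydrogen-bond acceptor counts, so these counts do not separate them, and no measurement is available to explain the step.

Whether the ring nitrogen of pyridin-2-yl is needed for this step remains open, since a phenyl group has not been paired with trifluoromethyl among the compounds shown. Also open, as far as these compounds go, is how an amine or a carboxylic acid on the pyridin-2-yl ring would read in this assay on this core.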